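The source may report more compounds than this note shows. Statements on the series, on what has been measured and on what is new or still open speak of the compounds shown alone.

Measured so far:
compound 1 `COC(=O)c1ccc(NC(=O)[C@H]2CC=C(CCC=C(C)C)C[C@@H]2c2ccccc2)cc1`: > 23000 nM
compound 2 `CC(C)=CCCC1=CC[C@@H](C(=O)Nc2ccc(C(=O)O)cc2)[C@H](c2ccccc2)C1`: 2200 nM
compound 3 `COC(=O)c1ccc(NC(=O)[C@@H]2CC=C(CCC=C(C)C)C[C@H]2c2ccccc2)cc1`: > 23000 nM

In an assay on isolated protein for inhibition of Apoptosis regulator Bcl-2 (Homo sapiens), read by fluorescence polarization, with stated times of 5 min and 10 min (on this read-out lower numbers stand for stronger inhibition and higher numbers for weaker inhibition), compound 1 gives > 23000 nM, which is a limit of the assay and not a number. Compound 3 likewise sits at a limit, > 23000 nM. Compound 2 gives 2200 nM. The step of an at least 10-fold higher number from compound 2 to compound 3 (1.01 log units; beyond the scatter) is large; the step that the two limits leave unreadable from compound 1 to compound 3 cannot be read, since both ends sit at the limit (the limit of > 23000 nM in this assay, at which 2 of the 3 values shown sit).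

Compound 4 `CONC(=O)[C@H]1CC=C(CCC=C(C)C)C[C@@H]1c1ccccc1` differs from compound 1 by methoxy in place of 4-(methoxycarbonyl)phenyl on an amide-type nitrogen. For the measured compounds named here, no measured step touches this change; both measured steps concern the ester or the configuration, and compound 1 itself is known only as a limit (the limit of > 23000 nM in this assay, at which 2 of the 3 values shown sit). The expected step that the limit leaves unreadable from compound 1 to compound 4 is therefore none readable. Compound 4 is estimated at 40000 nM, with a range of 10000 nM to 200000 nM.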

Compound 4, inhibition constant: 2400 nM
Beside the measured number, compound 4's estimate is 17-fold (1.22 log units) above it; measured number outside the range, below it.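

On the amide-type nitrogen, methoxy in place of 4-(methoxycarbonyl)phenyl gives an at least 9.5-fold lower number from compound 1 to compound 4 (0.98 log units; beyond the scatter) in this assay, so a measurable value at this position does not require the aromatic ring or its ester. For compound 1, > 23000 nM is a limit of the assay and not a number: the limit of > 23000 nM in this assay, at which 2 of the 4 values shown sit. The steps among compound 1, compound 2 and compound 3 touch only the ester and the configuration, not the whole group on this nitrogen.

Going by these compounds, whether the change in value comes from methoxy itself or from the loss of 4-(methoxycarbonyl)phenyl stays open. On these data alone, how a hydroxy, ethoxy or benzyloxy group on this nitrogen would read also stays open.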